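Naphthalen-2-yl in place of 2,5-dimethoxyphenyl: compound 3

This account rests on a few compounds, and the source may have more. Where it says the series, first, only, none or still open, it means among the compounds named here.

Among the measured compounds shown here, in a functional assay on HeLa cells (Homo sapiens) for inhibition, read by MTT assay, with a stated time of 48 h (on this read-out higher numbers stand for weaker inhibition and lower numbers for stronger inhibition), compound 1 (`COc1ccc(C(c2c[nH]c3ccc(Br)cc23)c2c[nH]c3ccc(Br)cc23)cc1`) gives 5500 nM and compound 2 (`COc1ccc(OC)c(C(c2c[nH]c3ccc(Br)cc23)c2c[nH]c3ccc(Br)cc23)c1`) gives 5100 nM as the only numbers so far. These two values lie within the scatter of each other, so compound 2 stands level with compound 1 on the available data.

Compound 3 (`Brc1ccc2[nH]cc(C(c3ccc4ccccc4c3)c3c[nH]c4ccc(Br)cc34)c2c1`) carries naphthalen-2-yl in place of 2,5-dimethoxyphenyl on a saturated chain carbon bound to two aromatic carbons. For the measured compounds named here, one measured step bears on this change, as it exchanges one group for another at the same place (a 1.1-fold lower number from compound 1 to compound 2 (0.03 log units; within the scatter)), and that step stays within the scatter. Going by the values given here, no measured compound carries naphthalen-2-yl, so this evidence is thin and the range is kept wide. Among the compounds with values here, on the single step from compound 1 to compound 2 (a 1.1-fold lower number from compound 1 to compound 2 (0.03 log units; within the scatter)), no shift beyond the scatter is expected in this assay, in either direction. The estimated step is correspondingly small (a 1.0-fold lower number from compound 2 to compound 3 (0.01 log units; within the scatter)) and remains an expectation. For compound 3 the expected value is 5000 nM within an estimated range of 2000 nM to 12000 nM at this stage.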

Compound 3, half-maximal inhibitory concentration: 4300 nM
Compound 3: the middle estimate sits 1.2-fold (0.07 log units) above what was measured; measured number inside the range.
By their numbers in this assay, from the lowest: compounds 3, 2 and 1 (each within the scatter of the next).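

In this assay, naphthalen-2-yl in place of 2,5-dimethoxyphenyl on a saturated chain carbon bound to two aromatic carbons gives a 1.2-fold lower number from compound 2 to compound 3 (0.07 log units; within the scatter) and stays within the scatter, and naphthalen-2-yl in place of 4-methoxyphenyl gives a 1.3-fold lower number from compound 1 to compound 3 (0.11 log units; within the scatter) and also stays within the scatter. Compounds 1 and 2 compared only methoxy-bearing phenyl groups, whereas compound 3 shows that a group of carbon only, with two six-membered aromatic rings and 0 hydrogen-bond acceptors, leaves the number level with both of them, so neither the methoxy oxygens nor a single ring is required at this place to hold this level among these three compounds. Nothing measured here accounts for these small steps.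

All three groups at this place are uncharged aromatic groups without hydrogen-bond donors, so the compounds shown do not reveal whether any change at this place can move the number beyond the scatter. An amine, a carboxylic acid or a longer saturated chain in this place remains an open test, as does any change to the bromine atoms of the shared core.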